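Swapping an amide for an amino ester on the shared core

A few compounds are considered here, and "the series" means these few. Any claim that something is new, unique, unknown or untested is made for them only; others in the source may bear on it.

Compound 1 `CC(C)(C)OC(=O)Nc1ncc(C(Oc2ccc3cc(Br)ccc3c2)c2ccc(Cl)cc2)s1`, compound 2 `COCCNc1ncc(C(Oc2ccc3cc(Br)ccc3c2)c2ccc(Cl)cc2)s1` and compound 3 `COC(=O)CCCCNc1ncc(C(Oc2ccc3cc(Br)ccc3c2)c2ccc(Cl)cc2)s1` share one core and differ only in the group on the nitrogen of the aromatic ring. In an ADME assay on HepG2 2.2.15 cells (Homo sapiens) for cytotoxicity (on this read-out lower numbers stand for higher toxicity in this test and higher numbers for lower toxicity in this test), compound 1 reaches only a limit of the test, > 50000 nM. In this assay compound 2 is recorded as "not toxic" (no number reported). Compound 3 stands alongside it: in this assay compound 3 is also recorded as "not toxic" (no number reported), so no single number places it against the others. Compound 1 alone sits at a limit of the test, as the limit of > 50000 nM in this assay, at which 1 of the 3 values shown sits, notes. Compound 2 carries no number at all. Compound 4 `CC(C)(C)C(=O)Nc1ncc(C(Oc2ccc3cc(Br)ccc3c2)c2ccc(Cl)cc2)s1` has not been tested. Its change from compound 3 reads: (tert-butyl)carbonyl in place of 4-(methoxycarbonyl)butyl on a nitrogen on an aromatic ring. Going by the values given here, with no measured step between related pairs in hand, the expected change in this assay is none beyond the scatter, since all three tested compounds show no toxicity in this cell line. For compound 4 the expected half-maximal cytotoxic concentration is therefore estimated at 50000 nM, with a range from 20000 nM to 100000 nM, and the result may well again be only a limit.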

Compound 4, half-maximal cytotoxic concentration: "not toxic" (no number reported)
The entry for compound 4 holds no number; there is nothing to compare the estimate with.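

In this assay compound 3 and compound 4 are both recorded only as not toxic, with no number, so no step can be read between them. The compounds shown leave open at what concentration the shared core becomes toxic to these cells, as the only figure is a limit: the limit of > 50000 nM in this assay, at which 1 of the 4 values shown sits.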